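Amine substituent change from compound 2 to compound 3

The source may hold more compounds than are shown below. What is called first, only, known or untested is meant among the compounds shown, and "the series" means these compounds.

Going by the values given here, in a functional assay on blood (Homo sapiens) for inhibition (on this read-out lower numbers stand for stronger inhibition and higher numbers for weaker inhibition), compound 1 (`CCC(C)CNc1cc(-c2[nH]c(SC)nc2-c2ccc(F)cc2)ccn1`) gives 2760 nM as the only number so far. Compound 2 (`CSc1nc(-c2ccc(F)cc2)c(-c2ccnc(NC3CCc4ccccc43)c2)[nH]1`) has no number in this assay: its entry reads "not determined" (no result reported) and so gives no starting point. Compound 3 (`CSc1nc(-c2ccc(F)cc2)c(-c2ccnc(NC(C)CCc3ccccc3)c2)[nH]1`) carries 1-methyl-3-phenylpropyl in place of 2,3-dihydro-1H-inden-1-yl on a nitrogen on an aromatic ring and keeps the shared core. No measured step sizes this change, so any expectation is loose. In this assay a moderate step toward stronger inhibition is expected, with the reading of compound 1 at 2760 nM as the only reference point. For compound 3 the estimated value is 1200 nM with an expected range from 300 nM to 4500 nM in this series.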

Compound 3, half-maximal inhibitory concentration: 2370 nM
Beside the measured number, compound 3's estimate is 2.0-fold (0.30 log units) below it; measured number inside the range.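

In this assay, the swap of 2-methylbutyl for 1-methyl-3-phenylpropyl on a nitrogen on an aromatic ring gives a 1.2-fold lower number from compound 1 to compound 3 (0.07 log units; within the scatter), so these two substituents cannot be told apart on this read-out. The added six-membered aromatic ring of carbon only therefore brings no change beyond the scatter at this position, which a single value could not show, while the step from compound 2 to compound 3 cannot be read. Nothing available bears on why the two substituents read alike.

The compounds shown leave open how the ring-closed 2,3-dihydro-1H-inden-1-yl compares with its open-chain counterpart at this nitrogen. They also leave open whether a longer chain, a hydroxyl group or a carboxylic acid on the substituent would move the number beyond the scatter.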